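Compound 3 loses its hydroxy group

This account rests on a few compounds, and the source may have more. Where it says the series, first, only, none or still open, it means among the compounds named here.

In an ADME assay on cells (Hepatocyte, Mus musculus) for metabolic stability, with a stated time of 30 min (on this read-out lower numbers stand for a less stable compound and higher numbers for a more stable compound), compound 1 `NC1CCC(CN2CCN(c3cc(=O)c4cc(C(F)(F)F)cc([N+](=O)[O-])c4s3)CC2)CC1` gives 107% and compound 2 `O=c1cc(N2CCN(CC3CCC(NS(=O)(=O)c4ccccc4)CC3)CC2)sc2c([N+](=O)[O-])cc(C(F)(F)F)cc12` gives 95.3%. Compound 3 `O=c1cc(N2CCN(CC3CCCCC3)CC2)sc2c(NO)cc(C(F)(F)F)cc12` stands lowest of the three at 47.8%. Compound 4 `Nc1cc(C(F)(F)F)cc2c(=O)cc(N3CCN(CC4CCCCC4)CC3)sc12` differs from it by hydrogen in place of hydroxy on a nitrogen on an aromatic ring. Going by the values given here, the only measured step between close neighbours, a number 11.7 percentage points lower from compound 1 to compound 2 (beyond the scatter), is a different change, phenylsulfonyl in place of hydrogen on an amine nitrogen, so it serves only as a gauge of size. Among the compounds with values here, no measured pair shows the present change. A moderate rise is expected, though on thin evidence, and the estimated move is a number 12.2 percentage points higher from compound 3 to compound 4 (beyond the scatter). For compound 4 the estimated value is 60%, with an expected range of 35% to 85%.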

Compound 4, percent of the compound remaining: 69.4%
Compound 4: the middle estimate sits 9.4 percentage points below what was measured, within the range that was stated.
By their numbers in this assay, from the lowest: compound 3; then compound 4; then compound 2; then compound 1.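

Hydroxyamino to amino, on a nitrogen on an aromatic ring, gives the first direct reading at this place: in this assay the change amounts to a number 21.6 percentage points higher from compound 3 to compound 4 (beyond the scatter). The earlier step concerned a different place, an amine nitrogen, whereas here the loss of one hydroxy alone moves the number beyond the scatter. Nothing available bears on why the number moves.

Still open, on these data alone, is how an acetyl or methyl group on this nitrogen would read in this assay. Also open, as far as these compounds go, is whether the same change gives a similar step with the side chains of compound 1 and compound 2.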